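The source may report more compounds than this note shows. Statements on the series, on what has been measured and on what is new or still open speak of the compounds shown alone.

Compound 1 `Cc1ccc2c(c1)/C(=N/NC(=S)NO)C(=O)N2CN1CCN(c2ccccc2)CC1` and compound 2 `O=C1/C(=N\NC(=S)NO)c2cc(Cl)ccc2N1CN1CCN(c2ccccc2)CC1` share one core; compound 3 `CCn1cc(C(=O)O)c(=O)c2cc(F)c(N3CCN(CN4C(=O)/C(=N\NC(=S)NOC)c5cc(C)ccc54)C(C)C3)c(F)c21` and compound 4 `CCn1cc(C(=O)O)c(=O)c2cc(F)c(N3CCN(CN4C(=O)/C(=N\NC(=S)NOC)c5cc(Cl)ccc54)C(C)C3)c(F)c21` share another, and the difference between the two cores is not broken down here. In an ADME assay on MT4 cells (Homo sapiens) for cytotoxicity, read by spectrophotometry, with a stated time of 5 days (a lower number here means that less compound is tolerated, a higher number that more compound is tolerated), compound 1 gives 420000 nM. Compound 2 is made from compound 1 by a single change, (chloro in place of methyl on an aromatic carbon), and in this assay compound 2 gives 273000 nM. The step measured is a 1.5-fold lower number from compound 1 to compound 2 (0.19 log units; within the scatter). Compound 3 gives 156000 nM in this assay; against compound 2 this lies within the scatter, against compound 1 beyond it. Compound 4 carries the same change on the second core, (chloro in place of methyl on an aromatic carbon), the change occurring twice among these compounds and measured once. Among the measured compounds shown here, since the one measured instance gave only a 1.5-fold lower number from compound 1 to compound 2 (0.19 log units; within the scatter), the step expected for compound 4 is a 1.4-fold lower number from compound 3 to compound 4 (0.15 log units; within the scatter), resting on that single pair alone. On this basis compound 4 is expected to give about 110000 nM in this assay, most likely between 55000 nM and 220000 nM.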

Compound 4, half-maximal cytotoxic concentration: 180000 nM
Compound 4: middle estimate off by 1.6-fold (0.21 log units), on the low side, within the range that was stated.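

Chloro in place of methyl on an aromatic carbon has now been read on the second core in this assay, giving a 1.2-fold higher number from compound 3 to compound 4 (0.06 log units; within the scatter). Set beside the step on the first core, the new step does not stand apart: the same change on two cores in this assay, a 1.5-fold lower number (0.19 log units; within the scatter) from compound 1 to compound 2 and a 1.2-fold higher number (0.06 log units; within the scatter) from compound 3 to compound 4, 1.8-fold (0.25 log units) apart, within the scatter of two such steps. Among the compounds shown here, on these two pairs the change moves the number beyond the scatter on neither core, which is consistent with a small step that carries from one core to the other, but it fixes no direction for the step, does not show that the step is identical on both cores, and rests on one pair per core.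

The compounds shown leave open how other groups on this aromatic carbon, such as bromo, methoxy or nitro, would compare with methyl and chloro on either core. Also open, on these data alone, is whether a step this small would hold on any core beyond these two.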